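The source may report more compounds than this note shows. Statements on the series, on what has been measured and on what is new or still open speak of the compounds shown alone.

Measured so far:
compound 1 `CN(C)c1ncnc2c1ncn2CC1CCC1`: 8 mg/kg
compound 2 `CC(C1CC1)n1cnc2c(N(C=O)C3CC3)ncnc21`: 2.5 mg/kg

Within the data shown here, in a functional assay on the whole organism for antagonist activity, with Rattus norvegicus as the target (on this read-out higher numbers stand for an effect only at larger amounts of compound and lower numbers for an effect already at smaller amounts), compound 2 gives the lower of the two numbers, and compound 1 gives 8 mg/kg, a gap beyond the usual scatter; the two differ in more than one place, so no single step connects them. Compound 3 `O=CN(c1ncnc2c1ncn2CC1CCC1)C1CC1` keeps the formyl-cyclopropyl amide of compound 2 and carries the change (cyclobutylmethyl in place of 1-cyclopropylethyl on an aromatic nitrogen). Among the measured compounds shown here, no measured step covers this change, so the direction rests on expectation alone. The expected step of a 1.6-fold higher number from compound 2 to compound 3 (0.20 log units; within the scatter) is small, toward higher numbers, and within the scatter. For compound 3 the estimate in this assay is 4 mg/kg, range 1.5 mg/kg to 12 mg/kg.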

Compound 3, dose for half-maximal effect: 7 mg/kg
Beside the measured number, compound 3's estimate is 1.8-fold (0.24 log units) below it; measured number inside the range.
By their numbers in this assay, from the lowest: compound 2; then compounds 3 and 1 (each within the scatter of the next).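

On the aromatic nitrogen, with the formyl-cyclopropyl amide held constant, cyclobutylmethyl in place of 1-cyclopropylethyl gives a 2.8-fold higher number from compound 2 to compound 3 (0.45 log units; beyond the scatter) in this assay, so two groups of equal heavy-atom count are not interchangeable at this position. With cyclobutylmethyl held constant, cyclopropyl(formyl)amino in place of dimethylamino on the aromatic carbon gives a 1.1-fold lower number from compound 1 to compound 3 (0.06 log units; within the scatter), so that change does not separate this pair. No measurement bears on the reason for either result.

Still open, from the compounds shown here alone, is whether the amide change gives the same result with 1-cyclopropylethyl on the aromatic nitrogen. Also open, going by these compounds, is how a straight pentyl chain or a benzyl group would compare at that position.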